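The source may report more compounds than this note shows. Statements on the series, on what has been measured and on what is new or still open speak of the compounds shown alone.

In an ADME assay on MT4 cells (Homo sapiens) for cytotoxicity, with a stated time of 5 days (a higher number here means that more compound is tolerated, a lower number that less compound is tolerated), only two results exist so far. Compound 1 `O=c1[nH]c2ccc(Cl)cc2n1S(=O)(=O)c1c(Cl)cccc1Cl` gives > 331000 nM, and this is a limit of the assay rather than a number. Among the measured compounds shown here, compound 2 `O=C(CCl)Nc1ccc(Cl)cc1NS(=O)(=O)c1c(Cl)cccc1Cl` gives 160000 nM, the only actual number available, so there is no measured series against which to rank it.

Compound 3 `N#Cc1cccc(S(=O)(=O)Nc2cc(Cl)ccc2NC(=O)CCl)c1` differs from compound 2 in one place: 3-cyanophenyl in place of 2,6-dichlorophenyl on a sulfonyl sulfur. In words, 3-cyanophenyl stands in place of 2,6-dichlorophenyl on a sulfonyl sulfur. For the measured compounds named here, no measured pair of compounds differs in just one place, so the data do not show what a swap of this kind does. The expectation in this assay is therefore for no shift beyond the usual scatter, in either direction. The expected change is a 1.1-fold lower number from compound 2 to compound 3 (0.03 log units; within the scatter). For compound 3 the estimate is 150000 nM, with an expected range of 60000 nM to 320000 nM.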

Compound 3, half-maximal cytotoxic concentration: > 155000 nM
Compound 3: a limit, no number (the forecaster's own chance of this, stated with the estimate: 30%); at least 1.0-fold (0.01 log units) between middle value and limit.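

In this assay compound 3 gives > 155000 nM, which is a limit and not a number. Among the compounds shown here, no step from compound 2 to compound 3 can therefore be read. The compounds shown leave open whether 3-cyanophenyl in place of 2,6-dichlorophenyl changes how much compound is tolerated.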